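This account rests on a few compounds, and the source may have more. Where it says the series, first, only, none or still open, it means among the compounds named here.

Values in an ADME assay on HEK293 cells (Homo sapiens) for cytotoxicity, read by luminescence, with a stated time of 72 h (on this read-out lower numbers stand for an effect already at smaller amounts and higher numbers for an effect only at larger amounts of compound), follow here:

Compound 1 `CCOC(=O)c1c(-c2cccc(C)c2)[nH]c2cc(OC)ccc2c1=O` gives > 22000 nM (a limit)
Compound 2 `C=Cc1cccc(-c2[nH]c3cc(OC)ccc3c(=O)c2C(=O)OCC)c1` gives > 22000 nM (a limit)
Compound 3 `CCOC(=O)c1c(-c2cccc(OCc3ccccc3)c2)[nH]c2cc(OC)ccc2c1=O` gives > 22000 nM (a limit)

Each of these entries is a limit of the assay and not a number. Compound 3 stands at the limit of > 22000 nM in this assay, at which 3 of the 3 values shown sit, and has no number of its own. Compound 4 `CCOC(=O)c1c(-c2cccc(F)c2)[nH]c2cc(OC)ccc2c1=O` has fluoro in place of benzyloxy on an aromatic carbon. Among the measured compounds shown here, three measured steps bear on this change: a step that the two limits leave unreadable from compound 1 to compound 3 and a step that the two limits leave unreadable from compound 2 to compound 3 and also a step that the two limits leave unreadable from compound 1 to compound 2 give no size to build on. The expected change in this assay is therefore none beyond the scatter, an estimated a number no higher from compound 3 to compound 4 (the limit leaves the size open) with no direction foreseen. For compound 4 the estimate is 22000 nM with an expected range from 12000 nM to 30000 nM and a good chance of only a limit again.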

Compound 4, half-maximal effective concentration: > 22000 nM
Compound 4: no number, only a limit; the forecaster's own chance of this, stated with the estimate: 85%; the middle value sits exactly at the limit.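

No step can be read between compound 4 and compound 1, compound 2 or compound 3, because each has only a limit and no number: the limit of > 22000 nM in this assay, at which 4 of the 4 values shown sit. On these data alone, whether methyl, vinyl, benzyloxy or fluoro differ at all in this assay stays open.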